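A Fluoro Added to the Hydrazone Phenyl of Compound 3

This account rests on a few compounds, and the source may have more. Where it says the series, first, only, none or still open, it means among the compounds named here.

Of the compounds shown here, three sharing one core have been measured in a functional assay on HepG2 cells (Homo sapiens) for inhibition, read by MTT assay, with a stated time of 48 h; a lower number here means a stronger inhibitor, a higher number a weaker inhibitor. Compound 1 `Clc1ccccc1CSc1nnc(-c2ccncc2)n1-c1ccccc1` gives 15700 nM, compound 2 `Fc1ccc(CSc2nnc(-c3ccncc3)n2-c2ccccc2)cc1` gives 15600 nM, and compound 3 `O=C(CSc1nnc(-c2ccncc2)n1-c1ccccc1)N/N=C/c1ccccc1` gives 18600 nM. The number for compound 3 sits together with those of compound 1 and compound 2, the gaps to each of them falling within the usual scatter, so no ranking among the three can be read from these values.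

Compound 4 `O=C(CSc1nnc(-c2ccncc2)n1-c1ccccc1)N/N=C/c1ccccc1F` differs from compound 3 by one change: fluoro in place of hydrogen on an aromatic carbon. Within the data shown here, the only measured step in this set, a 1.0-fold lower number from compound 1 to compound 2 (0.00 log units; within the scatter), concerns a swap of the aryl group on the saturated chain carbon bound to a sulfur, a different part of the molecule from the hydrazone phenyl altered here, and it produced no shift beyond the scatter. Among the measured compounds shown here, no measured pair tells directly what a fluoro on this phenyl does.

For the measured compounds named here, with no step bearing on this position and the one recorded step being flat, the expectation for compound 4 in this assay is a step no larger than the scatter, a 1.0-fold lower number from compound 3 to compound 4 (0.01 log units; within the scatter). Compound 4 is therefore estimated at 18000 nM, with a range from 8500 nM to 38000 nM.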

Compound 4, half-maximal inhibitory concentration: 15200 nM
For compound 4 the middle estimate is 1.2-fold (0.07 log units) above the measured one; low and high end bracket the measured number.
By their numbers in this assay, from the lowest: compounds 4, 2, 1 and 3 (each within the scatter of the next).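

In this assay the hydrazone phenyl now has a measured step of its own: fluoro in place of hydrogen on an aromatic carbon, ortho to a large group, gives a 1.2-fold lower number from compound 3 to compound 4 (0.09 log units; within the scatter) on going from phenyl to 2-fluorophenyl. Among these compounds, this single fluoro therefore leaves the number within the scatter, and the earlier compounds could not show this, since their only step, a 1.0-fold lower number from compound 1 to compound 2 (0.00 log units; within the scatter), concerns the aryl group on the saturated chain carbon bound to a sulfur and not this ring. Nothing measured beyond these numbers bears on the result, so the flat step stays a plain observation without an explanation.

The compounds shown leave open whether a different group at this same place, such as a methoxy group, an amine, a carboxylic acid or a trifluoromethyl group, would give a step beyond the scatter. They also leave open whether fluoro on another carbon of this ring, or a second fluoro on it, would stay as flat as this one.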